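Trifluoromethyl in place of methoxy: what to expect

The source may hold more compounds than are shown below. What is called first, only, known or untested is meant among the compounds shown, and "the series" means these compounds.

Compound 1 `CCN(CC)c1ccc(-c2cccc(OC)c2)nn1` has been tested in an ADME assay on HaCaT cells (Homo sapiens) for antiproliferative activity, with a stated time of 48 h; on this read-out higher numbers stand for weaker inhibition and lower numbers for stronger inhibition. In this assay compound 1 gives > 25000 nM, which is a limit of the assay and not a number. Compound 2 `COC(=O)c1cccc(-c2ccc(-n3cccc3)nn2)c1` gives > 25000 nM, which is also a limit. Compound 3 `COc1ccc(Nc2ccc(-c3ccccc3)nn2)cc1` gives > 25000 nM, a limit once more. For the measured compounds named here, no measured compound therefore offers an exact number for comparison.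

The next compound, compound 4 `CCN(CC)c1ccc(-c2cccc(C(F)(F)F)c2)nn1`, keeps the core of compound 1 but has trifluoromethyl in place of methoxy on an aromatic carbon, meta to a large group (trifluoromethyl in place of methoxy on an aromatic carbon). Going by the values given here, no measured step shows what such a swap does here. The expectation rests only on compound 1 and the two others sharing one reading, (the limit of > 25000 nM in this assay, at which 3 of the 3 values shown sit). The expected result is a number no higher from compound 1 to compound 4 (the limit leaves the size open), meaning no shift beyond the usual scatter in this assay and no favoured direction. The assay may well report only a limit again. Compound 4 is estimated at 25000 nM, with an expected range from 10000 nM to 50000 nM.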

Compound 4, half-maximal inhibitory concentration: > 25000 nM
Compound 4 ended at the assay's limit; the forecaster's own chance of this, stated with the estimate: 70%; the middle value sits exactly at the limit.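

In this assay, for the compounds shown here, compound 1 and compound 4 both stop at the assay's limit, so swapping methoxy for trifluoromethyl gives no step that can be read. The compounds shown leave open how strongly any of them inhibits, because all share one reading: the limit of > 25000 nM in this assay, at which 4 of the 4 values shown sit.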